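Aryl exchange on compound 2: first working notes

A few compounds are considered here, and "the series" means these few. Any claim that something is new, unique, unknown or untested is made for them only; others in the source may bear on it.

In a functional assay on A549 cells (Homo sapiens) for inhibition, read by CCK-8 assay, with a stated time of 48 h (a lower number here means a stronger inhibitor, a higher number a weaker inhibitor), compound 1 `COc1cc(-c2cc3nccc(-c4cc(OC)c(OC)c(OC)c4)n3n2)cc(OC)c1OC` gives > 10000 nM as a limit of the assay, not a number. Among the compounds with values here, compound 2 `COc1cc(-c2ccnc3cc(-c4ccc(C)c(C)c4)nn23)cc(OC)c1OC` gives 272 nM as the only true number so far. Compound 3 `COc1cc(-c2ccnc3cc(-c4ccc(N(C)C)cc4)nn23)cc(OC)c1OC` carries 4-(dimethylamino)phenyl in place of 3,4-dimethylphenyl on an aromatic carbon. Within the data shown here, no measured pair shows this change. In this assay the expectation starts from compound 2 at 272 nM and foresees no move beyond the scatter. The estimated step is a 1.4-fold lower number from compound 2 to compound 3 (0.13 log units; within the scatter) and leans slightly toward stronger inhibition. For compound 3 the estimate is 200 nM within an expected range of 40 nM to 1000 nM for now.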

Compound 3, half-maximal inhibitory concentration: 1100 nM
Beside the measured number, compound 3's estimate is 5.5-fold (0.74 log units) below it; the whole stated range lies below it.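

Within the data shown here, at this position, on an aromatic carbon of a five-membered aromatic ring with 2 nitrogen, the aryl exchange gives the first step between two true numbers: in this assay, 4-(dimethylamino)phenyl in place of 3,4-dimethylphenyl gives a 4.0-fold higher number from compound 2 to compound 3 (0.61 log units; beyond the scatter). Compound 2 therefore remains the stronger inhibitor of this pair. Nothing available accounts for this step.

Still open, as far as these compounds go, is whether the step belongs to the dimethylamino group or to the departure of the 3,4-dimethyl pattern. From the compounds shown here alone, how a phenyl carrying a morpholine or a carboxylic acid would read here also remains open.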